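Swapping the Amine Chain for a Methyl Ester

The compounds below may be only part of what the source reports. "The series", "measured", "known", "first", "only" and "open" are said of these compounds alone.

Compound 1, `NCCCNc1c(C(=O)NCc2ccc(F)cc2)nc(Br)c2cccnc12`, was tested in a functional assay on HCT-116 cells (Homo sapiens) for cytotoxicity, read by MTT assay, with a stated time of 72 h; on this read-out lower numbers stand for stronger inhibition and higher numbers for weaker inhibition. Compound 1 gives 18000 nM. Of the two compounds with a number, compound 1 has the higher one, meaning the weaker inhibition; compound 3, `CS(=O)(=O)NCCCN(c1nc(C(=O)NCc2ccc(F)cc2)c(O)c2ncccc12)S(C)(=O)=O`, gives 7000 nM. Compound 2, `CC(C)(C)OC(=O)N1CCN(c2c(C(=O)NCc3ccc(F)cc3)nc(Br)c3cccnc23)CC1`, reaches only a limit, > 10000 nM, not a number; this is the limit of > 10000 nM in this assay, at which 1 of the 3 values shown sits. Compound 4, `COC(=O)CNc1c(C(=O)NCc2ccc(F)cc2)nc(Br)c2cccnc12`, differs from compound 1 by a single change: methoxycarbonyl in place of 2-aminoethyl on a saturated chain carbon bound to a nitrogen on an aromatic ring. For the measured compounds named here, no measured pair in this set shows the effect of such a change, so the expectation rests on compound 1 alone. The expected step is a 1.1-fold higher number from compound 1 to compound 4 (0.05 log units; within the scatter), no more than the scatter. Compound 4 is estimated at 20000 nM, with a range from 7000 nM to 60000 nM.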

Compound 4, half-maximal inhibitory concentration: > 10000 nM
Compound 4: a limit, no number; the forecaster's own chance of this, stated with the estimate: 40%; the middle value lies beyond the limit too.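

Compound 4 reaches only a limit, > 10000 nM, not a number, so the step from compound 1 to compound 4 cannot be read. As far as these compounds go, how far methoxycarbonyl in place of 2-aminoethyl shifts the number in this assay stays open.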